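This account rests on a few compounds, and the source may have more. Where it says the series, first, only, none or still open, it means among the compounds named here.

Of the compounds shown here, three sharing one core have been tested in a functional assay on KYSE-70 cells for antiproliferative activity against KYSE-70 cell line (Homo sapiens), read by MTT assay, with a stated time of 72 h; on this read-out higher numbers stand for weaker inhibition and lower numbers for stronger inhibition. Compound 1 `O=C(c1ccnc2cc(Br)ccc12)N1CCCCC1` gives > 20000 nM, which is a limit and not a number. Compound 2 `COc1ccccc1NC(=O)c1ccnc2cc(Br)ccc12` gives > 20000 nM, again a limit. Compound 3 `O=C(Nc1ccc(F)cc1)c1ccnc2cc(Br)ccc12` gives > 20000 nM, also a limit. Compound 3 therefore stands with the other two at the limit of > 20000 nM in this assay, at which 3 of the 3 values shown sit, and no order among them can be read.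

Compound 4 `O=C(Nc1ccc(Cl)cc1)c1ccnc2cc(Br)ccc12` alters compound 3 in a single place: chloro in place of fluoro on an aromatic carbon. This puts chloro in place of fluoro on an aromatic carbon, para to a large group, and the rest of the molecule stays the same. For the measured compounds named here, no measured pair shows what this swap does in this assay, so the expectation is modest. The expected step of a number no higher from compound 3 to compound 4 (the limit leaves the size open) is none beyond the usual scatter, in neither direction. This expectation rests on compound 3, whose > 20000 nM is a limit. The estimate for compound 4 is 20000 nM, with an expected range of 8000 nM to 40000 nM, and a further limit is the likeliest report.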

Compound 4, half-maximal inhibitory concentration: > 20000 nM
Compound 4: no number, only a limit (the forecaster's own chance of this, stated with the estimate: 80%); the middle value lies on the limit itself.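

Compound 4 gives > 20000 nM, again a limit and not a number, so no step can be read from compound 3 to compound 4: the limit of > 20000 nM in this assay, at which 4 of the 4 values shown sit.

The compounds shown leave open how chloro and fluoro compare here, and whether any group on the shared core gives a number rather than a limit.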